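Compound 1 to compound 4: replacing the 4-methylphenyl

The source may hold more compounds than are shown below. What is called first, only, known or untested is meant among the compounds shown, and "the series" means these compounds.

Compound 1 `COc1cc(C(=O)/C=C/c2ccc(C)cc2)cc(OC)c1OC`: 50500 nM
Compound 2 `COc1cc(C(=O)/C=C/c2ccc([N+](=O)[O-])cc2)cc(OC)c1OC`: > 100000 nM (a limit)
Compound 3 `CCCCOc1ccc(/C=C/C(=O)c2cc(OC)c(OC)c(OC)c2)cc1`: > 100000 nM (a limit)

Within the data shown here, in a functional assay on L1210 cells (Mus musculus) for cytotoxicity, read by MTT assay, with a stated time of 24 h (on this read-out lower numbers stand for stronger inhibition and higher numbers for weaker inhibition), compound 1 gives 50500 nM, the only true number in the set. The two other values are limits, as the limit of > 100000 nM in this assay, at which 2 of the 3 values shown sit, shows. Compound 4 `COc1cc(C(=O)/C=C/c2cc(Cl)cc(Cl)c2)cc(OC)c1OC` has not yet been measured, and its change is 3,5-dichlorophenyl in place of 4-methylphenyl on a double-bonded chain carbon bound to a double-bonded chain carbon. Among the measured compounds shown here, two measured steps bear on it, both altering the same aromatic group: an at least 1.9-fold higher number from compound 1 to compound 2 (0.29 log units; that floor lies within the scatter) and an at least 1.9-fold higher number from compound 1 to compound 3 (0.29 log units; that floor lies within the scatter). Neither shows a change beyond the scatter, so no clear step is expected in this assay, and the expected step is a 1.2-fold higher number from compound 1 to compound 4 (0.07 log units; within the scatter). For compound 4 the estimated value is 60000 nM, with an expected range from 20000 nM to 100000 nM.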

Compound 4, half-maximal inhibitory concentration: 44000 nM
Beside the measured number, compound 4's estimate is 1.4-fold (0.13 log units) above it; measured number inside the range.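

In this assay, among these compounds, this change gives the first step at this position whose size can be read: a 1.1-fold lower number from compound 1 to compound 4 (0.06 log units; within the scatter). Compounds 2 and 3 stand only at a limit, so their steps give a floor and nothing more. The 3,5-dichlorophenyl, by contrast, gives a true number that stays within the scatter of compound 1, so this exchange of aromatic groups makes no readable difference.

As far as these compounds go, it remains open how far compounds 2 and 3 lie past that limit, and whether a phenyl carrying an amine or a carboxylic acid here would move the number clearly away from compound 1.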